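Replacing the Bromine on the Core of Compound 1

A few compounds are considered here, and "the series" means these few. Any claim that something is new, unique, unknown or untested is made for them only; others in the source may bear on it.

Compound 1 `O=C(NCCCNc1nc(Nc2cccc(F)c2)ncc1Br)C1CCC1` is the strongest of the three measured compounds in an assay on isolated protein for inhibition of serine/threonine-protein kinase TBK1 (Homo sapiens) (on this read-out higher numbers stand for weaker inhibition and lower numbers for stronger inhibition), where compound 1 gives 2 nM. The other two differ from it only in the group on the carbonyl carbon: compound 2 `O=C(CCc1ccccc1)NCCCNc1nc(Nc2cccc(F)c2)ncc1Br` gives 560 nM and compound 3 `CC(=O)N1CCC(C(=O)NCCCNc2nc(Nc3cccc(F)c3)ncc2Br)CC1` gives 430 nM. Both changes cost dearly, a 280-fold higher number from compound 1 to compound 2 (2.45 log units; beyond the scatter) and a 220-fold higher number from compound 1 to compound 3 (2.33 log units; beyond the scatter), while the two larger amides sit close together, a 1.3-fold lower number from compound 2 to compound 3 (0.11 log units; within the scatter).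

Compound 4 `O=C(NCCCNc1nc(Nc2cccc(F)c2)ncc1CC1CC1)C1CCC1` keeps the cyclobutyl amide of compound 1 and changes a different place: cyclopropylmethyl in place of bromo on an aromatic carbon. Within the data shown here, none of the measured steps touches this aromatic carbon; all three concern the group on the carbonyl carbon, so they do not bear on the new change. Compound 1, which gives 2 nM, is therefore the only anchor. A modest weakening for compound 4 is expected on that basis, a 7.5-fold higher number from compound 1 to compound 4 (0.88 log units; beyond the scatter), with wide uncertainty. Compound 4 is estimated at 15 nM, expected to fall between 2 nM and 150 nM.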

Compound 4, half-maximal inhibitory concentration: > 1000 nM
Compound 4: only a limit was reported; the forecaster's own chance of this, stated with the estimate: 0%; at least 66-fold (1.82 log units) between middle value and limit.
By their numbers in this assay, from the lowest: compound 1; then compounds 3 and 2 (each within the scatter of the next). At a limit, above all of these: compound 4.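

The aromatic carbon para to a (3-fluorophenyl)amino group proves to be a second place where a single change costs a large step: with the cyclobutyl amide held constant in this assay, cyclopropylmethyl in place of bromo gives an at least 500-fold higher number from compound 1 to compound 4 (2.69 log units; beyond the scatter). The cyclobutyl amide, the best of the groups shown on the carbonyl carbon, therefore does not protect the compound against this change on the core. Compound 4 carries a limit of the assay and not a number, so the full size of the step stays unknown: the limit of > 1000 nM in this assay, at which 1 of the 4 values shown sits.

The compounds shown leave open whether the loss goes with the bromine leaving or with the four carbon atoms and three-membered ring entering; chlorine, methyl or a nitrile on the same carbon would separate the two. They also leave open how compound 2 and compound 3 would respond to the same change.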